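Replacing carbamoyl with methoxy on compound 3

A few compounds are considered here, and "the series" means these few. Any claim that something is new, unique, unknown or untested is made for them only; others in the source may bear on it.

Of the compounds shown here, three have been measured so far in an in vitro ADME assay on microsomes from liver (Simiiformes) (a higher number here means that the compound lasts longer, a lower number that the compound disappears faster), and they give a first view of the half-life. Compound 1 (`CC(=O)c1ccc(CCCOc2c(C)cc(-c3noc(C(F)(F)F)n3)cc2C)o1`) reaches 1.05 h in this read-out. Compound 2 (`CCOc1cc(CCCOc2c(C)cc(-c3noc(C4CC4)n3)cc2C)on1`) shows > 2.5 h as a limit of the assay and not as a number. Compound 3 (`Cc1cc(CCCOc2c(C)cc(-c3noc(C(N)=O)n3)cc2C)on1`) reaches 2.3 h as the higher of the two actual numbers, and its gap to compound 1 lies beyond the scatter.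

Compound 4 (`COc1nc(-c2cc(C)c(OCCCc3cc(C)no3)c(C)c2)no1`) has methoxy in place of carbamoyl on an aromatic carbon, the 5-carbamoyl-1,2,4-oxadiazol-3-yl becoming 5-methoxy-1,2,4-oxadiazol-3-yl: methoxy in place of carbamoyl on an aromatic carbon in full. Within the data shown here, no measured pair differs in one place only, so the size of this change has no direct precedent. A small fall in this assay that stays within the scatter is expected, and the expected step is a 1.4-fold lower number from compound 3 to compound 4 (0.13 log units; within the scatter) on this estimate. For compound 4 the estimated half-life is 1.7 h with an expected range from 0.8 h to 2.8 h in this read-out.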

Compound 4, half-life: 0.55 h
Compound 4: middle estimate off by 3.1-fold (0.49 log units), on the high side; the whole stated range lies above it.
By their numbers in this assay, from the lowest: compounds 4 and 1 (each within the scatter of the next); then compound 3. At a limit, above all of these: compound 2.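

In this assay, among these compounds, methoxy in place of carbamoyl on this aromatic carbon gives a 4.2-fold lower number from compound 3 to compound 4 (0.62 log units; beyond the scatter), the first change that can be read at a single place. The group on the carbon next to the ring nitrogen and next to the ring oxygen therefore matters for the half-life with the rest of the molecule held fixed, and 5-carbamoyl-1,2,4-oxadiazol-3-yl and 5-methoxy-1,2,4-oxadiazol-3-yl are not interchangeable here. Among the compounds shown here, nothing measured so far bears on why the number falls.

As far as these compounds go, whether the fall follows the loss of carbamoyl or the arrival of methoxy remains open. An amine, a nitrile or a carboxylic acid on the same carbon, with the rest of the molecule unchanged, would help separate the two readings.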